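The source may report more compounds than this note shows. Statements on the series, on what has been measured and on what is new or still open speak of the compounds shown alone.

Measured compounds:
- compound 1, `Cc1ccc(N2CCn3c2n[nH]c(=O)c3=O)cc1`, 14%
- compound 2, `COc1ccccc1N1CCn2c1n[nH]c(=O)c2=O`, 1%
- compound 3, `N/N=C1\NCCN1c1cccc(Cl)c1`, 5%

These three compounds were tested in a functional assay on T47D cells (Homo sapiens) for cytotoxicity, with a stated time of 72 h, tested at 10 ug/mL; on this read-out higher numbers stand for a stronger effect at the one concentration tested and lower numbers for a weaker effect. In this assay compound 1 gives 14%, the highest of the three numbers, though its gap to compound 3 falls within the usual scatter of repeated measurements, and only its gap to compound 2 lies beyond that scatter. All three numbers are low, so none of the compounds produces a strong effect at the concentration tested.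

Compound 4, `COc1ccc(N2CCn3c2n[nH]c(=O)c3=O)cc1`, has not yet been measured in this assay. It is derived from compound 1 by a single change: methoxy in place of methyl on an aromatic carbon. Among the measured compounds shown here, no measured pair here differs in only one place, so there is no directly comparable step to lean on; the only guide is that every number so far sits near the bottom of the scale.

On that basis the step from compound 1 to compound 4 in this assay is expected to be small, with no clear direction beyond the scatter, and the estimated step is a number 4 percentage points lower from compound 1 to compound 4 (within the scatter). Compound 4 is therefore expected to give about 10%, with a range from 0% to 25%.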

Compound 4, a percentage reported as inhibition, at one concentration (the size of the read-out at that concentration, not a potency): 7%
Compound 4: middle estimate off by 3 percentage points, on the high side; the range from low to high includes it.
By their numbers in this assay, from the lowest: compounds 2, 3, 4 and 1 (each within the scatter of the next, the first and the last beyond it).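

In this assay, among the compounds shown here, the swap of methyl for methoxy on an aromatic carbon, para to a large group, provides the first comparison of two measured compounds that differ in one place: a number 7 percentage points lower from compound 1 to compound 4 (within the scatter). This step cannot be told apart from the ordinary variation between repeat measurements, so at this position, the extra oxygen and the hydrogen-bond acceptor it adds produce no clear difference in the read-out at the one concentration tested. No supporting measurement is available here to explain this result.

Because this is a single swap between two compounds with low numbers, it does not show whether the position matters in general, or whether the shared core simply gives little effect in these cells at this concentration. It also leaves open whether an amine, a carboxylic acid or a longer chain in the same place would give a number that differs from that of compound 1 by more than the scatter.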